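A few compounds are considered here, and "the series" means these few. Any claim that something is new, unique, unknown or untested is made for them only; others in the source may bear on it.

Working notes on the series. In an assay for binding affinity to Alpha-1A adrenergic receptor (Homo sapiens) (on this read-out higher numbers stand for weaker inhibition and lower numbers for stronger inhibition), compound 2 `CN(C)CCn1nc(Cc2ccc(Cl)cc2)c2ccccc2c1=O` gives 158 nM, the highest of the three numbers in hand. Compound 1 `O=c1c2ccccc2c(Cc2ccc(Cl)cc2)nn1C1CCCN(Cc2ccc(OCCCN3CCCCCC3)cc2)CC1` gives 100 nM, which lies within the scatter of compound 2. Compound 3 `O=c1c2ccccc2c(Cc2ccc(Cl)cc2)nn1C[C@H]1CCCN1CCCCCc1ccc(OCCCN2CCCCCC2)cc1` gives 25.1 nM, a lower number than compound 2 by a margin beyond the scatter. Compound 4 `CN1CCC(Cn2nc(Cc3ccc(Cl)cc3)c3ccccc3c2=O)C1` is unmeasured; it differs from compound 2 by 1-methylpyrrolidin-3-yl in place of (dimethylamino)methyl on a saturated chain carbon bound to an aromatic nitrogen. The three measured compounds show that a change near this chain carbon can move this assay, but none of them tests this particular exchange. The expected step from compound 2 to compound 4 is a 1.2-fold lower number from compound 2 to compound 4 (0.08 log units; within the scatter), none beyond the scatter. Compound 4 is estimated at 130 nM, with a range from 50 nM to 400 nM.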

Compound 4, inhibition constant: 100 nM
Estimate against measurement, compound 4: 1.3-fold (0.11 log units) above, and the stated range covers the measured number.
By their numbers in this assay, from the lowest: compound 3; then compounds 1, 4 and 2 (each within the scatter of the next).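

On the saturated chain carbon bound to an aromatic nitrogen, 1-methylpyrrolidin-3-yl in place of (dimethylamino)methyl gives a 1.6-fold lower number from compound 2 to compound 4 (0.20 log units; within the scatter) in this assay for this exchange. This position therefore accepts the five-membered non-aromatic ring, with its larger group, without a change that can be told from the scatter. No measured evidence bears on this result.

Still open, going by these compounds, is how this assay responds at this carbon to a 1-methylpiperidin-4-yl group or a carboxylic acid in place of 1-methylpyrrolidin-3-yl.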